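A few compounds are considered here, and "the series" means these few. Any claim that something is new, unique, unknown or untested is made for them only; others in the source may bear on it.

Compound 1, `CC(C)[C@H](NC(=O)COc1cccc2ccccc12)C(=O)N[C@@H](CC(=O)O)C(=O)CSc1nc[nH]n1`: in a functional assay on Jurkat cells (Homo sapiens) for inhibition (on this read-out higher numbers stand for weaker inhibition and lower numbers for stronger inhibition), compound 1 gives > 200000 nM, which is a limit of the assay rather than a number.
Compound 2, `CC(C)[C@H](NC(=O)COc1cccc2ccccc12)C(=O)N[C@@H](CC(=O)O)C(=O)CSc1nc2ccccc2[nH]1`: in this assay compound 2 gives > 200000 nM, again a limit and not a number.

Within the data shown here, compound 1 thus stands only at a limit, and compound 2 sits at the same limit, so the one measured step, a step that the two limits leave unreadable from compound 1 to compound 2, cannot be read. Compound 3, `CC(C)[C@H](NC(=O)COc1cccc2ccccc12)C(=O)N[C@@H](CC(=O)O)C(=O)COc1ccnc(C(F)(F)F)n1`, differs from compound 1 by (2-(trifluoromethyl)pyrimidin-4-yl)oxy in place of (1H-1,2,4-triazol-3-yl)sulfanyl on a saturated chain carbon bound to a carbonyl carbon. Among the measured compounds shown here, no measured step bears on this change, and the limit of > 200000 nM in this assay, at which 2 of the 2 values shown sit, says only where the limit lies. Compound 3 is therefore expected at about 50000 nM, with a range of 2000 nM to 200000 nM. That estimate means an at least 4.0-fold lower number from compound 1 to compound 3 (0.60 log units; beyond the scatter), held with little confidence.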

Compound 3, half-maximal inhibitory concentration: 37000 nM
Compound 3: the middle estimate sits 1.4-fold (0.13 log units) above what was measured, within the range that was stated.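

In this assay compound 3 is the only compound shown with a number rather than a limit, so a change at this position can bring measurable inhibition. Placing (2-(trifluoromethyl)pyrimidin-4-yl)oxy here gives an at least 5.4-fold lower number from compound 1 to compound 3 (0.73 log units; beyond the scatter), and the same group gives an at least 5.4-fold lower number from compound 2 to compound 3 (0.73 log units; beyond the scatter). Both steps are open-ended because compound 1 and compound 2 each stand only at a limit: the limit of > 200000 nM in this assay, at which 2 of the 3 values shown sit.

From the compounds shown here alone, whether the step belongs to the oxygen link, the ring or the trifluoromethyl stays open. A plain phenoxy group at this place would bear on that question.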